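Acetyl in Place of Trifluoromethoxy at the Cytotoxicity Limit

A few compounds are considered here, and "the series" means these few. Any claim that something is new, unique, unknown or untested is made for them only; others in the source may bear on it.

Compound 2 `CCOC(=O)c1c(-c2cccc(OC(F)(F)F)c2)[nH]c2cc(OC)ccc2c1=O` and its neighbour compound 1 `CCCCOc1cccc(-c2[nH]c3cc(OC)ccc3c(=O)c2C(=O)OCC)c1` belong to a small series tested in an ADME assay on HEK293 cells (Homo sapiens) for cytotoxicity, read by luminescence, with a stated time of 72 h; a higher number here means that more compound is needed for the effect, a lower number that less compound is needed. In this assay compound 1 gives only a limit of the assay, > 22000 nM. In this assay compound 2 likewise gives only a limit of the assay, > 22000 nM. Within the data shown here, the one measured step, a step that the two limits leave unreadable from compound 1 to compound 2, therefore runs between two limits, and its size cannot be read; the sole evidence on it is that (the limit of > 22000 nM in this assay, at which 2 of the 2 values shown sit). Compound 3 `CCOC(=O)c1c(-c2cccc(C(C)=O)c2)[nH]c2cc(OC)ccc2c1=O` differs from compound 2 in one place: acetyl in place of trifluoromethoxy on an aromatic carbon. Among the measured compounds shown here, no measured step in this set involves an acetyl group, so the pair of limits is the only guide available. Because (the limit of > 22000 nM in this assay, at which 2 of the 2 values shown sit), the expectation for compound 3 is that it will again sit at or beyond that limit, with no readable step. The step that the limit leaves unreadable from compound 2 to compound 3 is estimated to stay within the usual scatter. Compound 3 is expected to give 30000 nM in this assay, with a range from 15000 nM to 80000 nM.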

Compound 3, half-maximal effective concentration: > 22000 nM
Compound 3 gave a limit, no number (the forecaster's own chance of this, stated with the estimate: 80%); the middle value is on the limit's open side.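

In this assay compound 3 gives only a limit of the assay, > 22000 nM. No step among compound 1, compound 2 and compound 3 can be read, since every value is a limit: the limit of > 22000 nM in this assay, at which 3 of the 3 values shown sit.

The compounds shown leave open whether butoxy, trifluoromethoxy and acetyl differ at all in this cytotoxicity measurement.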